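Working notes: aniline replacement from compound 2 to compound 3

The source may report more compounds than this note shows. Statements on the series, on what has been measured and on what is new or still open speak of the compounds shown alone.

Compound 1, `S=c1oc(-c2ccc3c(c2)OCCO3)nn1CNc1ccccc1`, and compound 2, `S=c1oc(-c2ccc3c(c2)OCCO3)nn1CNc1ccccc1Cl`, share one core and differ only by chloro in place of hydrogen on an aromatic carbon. In a functional assay, with a stated time of 6 min (on this read-out higher numbers stand for weaker inhibition and lower numbers for stronger inhibition), compound 1 gives 5140 nM, and compound 2 gives 7230 nM. The step of a 1.4-fold higher number from compound 1 to compound 2 (0.15 log units; within the scatter) lies within the scatter. Going by the values given here, compound 2 carries the higher of the two numbers measured so far, but that gap is within the scatter and establishes no order between the two.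

Compound 3, `O=[N+]([O-])c1cccc(NCn2nc(-c3ccc4c(c3)OCCO4)oc2=S)c1`, has not been measured. Its change from compound 2 is 3-nitrophenyl in place of 2-chlorophenyl on an amine nitrogen. Among the compounds with values here, the only measured step, a 1.4-fold higher number from compound 1 to compound 2 (0.15 log units; within the scatter), also concerns the phenyl on the amine nitrogen and stayed within the scatter; nothing measured covers a nitro group, so the bearing on this change is indirect. On that basis the step is expected to be small, with no direction beyond the scatter: a 1.2-fold lower number from compound 2 to compound 3 (0.08 log units; within the scatter). For compound 3 the expected value in this assay is 6000 nM, with a range of 2500 nM to 15000 nM.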

Compound 3, half-maximal inhibitory concentration: 8870 nM
Beside the measured number, compound 3's estimate is 1.5-fold (0.17 log units) below it, within the range that was stated.
By their numbers in this assay, from the lowest: compounds 1, 2 and 3 (each within the scatter of the next).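

Working notes on the aniline position, continued

In this assay, the 3-nitrophenyl on the amine nitrogen, with 9 heavy atoms and 2 hydrogen-bond acceptors against 7 and 0 for the 2-chlorophenyl, gives a 1.2-fold higher number from compound 2 to compound 3 (0.09 log units; within the scatter) and so is not separated from it. Nitro in place of hydrogen reads the same way, with a 1.7-fold higher number from compound 1 to compound 3 (0.24 log units; within the scatter) as the step, so this substitution is also unresolved from the unsubstituted phenyl. The phenyl on the amine nitrogen has now carried hydrogen, chloro and nitro with no listed step beyond the scatter, although the step from compound 2 to compound 3 alters both the group and its printed ring position, so those two contributions cannot be told apart.

No evidence is available on what lies behind these close numbers. Still open, on these data alone, is whether an amine or a carboxylic acid on the phenyl, or a saturated ring in its place, would give a step beyond the scatter.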